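Permeability of a propyl amide among three furan and pyrazole carboxamides

This account rests on a few compounds, and the source may have more. Where it says the series, first, only, none or still open, it means among the compounds named here.

Of the compounds shown here, three have been measured in an ADME assay for permeability; on this read-out lower numbers stand for lower permeability and higher numbers for higher permeability. Compound 1 `CNC(=O)c1cc(C(=O)N[C@H]2CC[C@H](O)CC2)c([C@@H](C)c2ccc(Cl)cc2)o1` gives 150 nm/s in this assay. Compound 2 `CNC(=O)c1cc(C(=O)N[C@H]2[C@@H]3COC[C@@H]32)c([C@@H](C)c2ccccc2)o1` gives 200 nm/s. Compound 3 `CNC(=O)c1cc(C(=O)NC2CCOCC2)n([C@@H](C)c2ccccc2)n1` gives 270 nm/s. The number for compound 3 is the largest of the three, yet its gap to compound 2 and its gap to compound 1 both fall within the scatter of this kind of measurement, so the three compounds cannot be told apart on these numbers.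

Compound 4 `CCCNC(=O)c1cc(C(=O)NC)nn1[C@@H](C)c1ccccc1` has not yet been measured in this assay. It differs from compound 3 in one place: propyl in place of oxan-4-yl on an amide-type nitrogen. Within the data shown here, no step between two measured compounds describes this change, so its size in this assay is not known from the data at hand.

The author expects compound 4 to show a step of a 1.7-fold higher number from compound 3 to compound 4 (0.22 log units; within the scatter) in this assay. Compound 3, the starting point of that expected step, gives 270 nm/s. On that basis compound 4 is estimated at 450 nm/s in this assay, with a range from 220 nm/s to 900 nm/s.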

Compound 4, apparent permeability: 560 nm/s
Estimate against measurement, compound 4: 1.2-fold (0.09 log units) below, and the stated range covers the measured number.
By their numbers in this assay, from the lowest: compounds 1, 2 and 3 (each within the scatter of the next); then compound 4.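

In this assay, among these compounds, propyl in place of oxan-4-yl on the amide-type nitrogen gives a 2.1-fold higher number from compound 3 to compound 4 (0.32 log units; beyond the scatter), a modest change but the first in this small set that can be read as a step at all, since the earlier compounds differ in more than one place and their numbers lie within the scatter of one another. The change at this position therefore moves the number measurably, even though it replaces a six-membered non-aromatic ring holding 1 hydrogen-bond acceptor with a chain that has no ring and 0 hydrogen-bond acceptors, so the ring and the acceptor leave together and this single step cannot assign the rise to either one. Nothing at hand gives a measured reason for the rise.

The compounds shown leave open whether cyclohexyl, which keeps the ring without the oxygen, would fall with compound 3 or with compound 4, and whether a butyl chain would go further than propyl. They also leave open whether the same exchange on the amide-type nitrogen would give a similar step on the core of compound 2.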